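Adding a Second Methoxy to the Aryl Ring of Compound 3

The source may hold more compounds than are shown below. What is called first, only, known or untested is meant among the compounds shown, and "the series" means these compounds.

Three compounds share one core and differ only in the aromatic ring attached to it. Compound 1 `COc1cc2c(Oc3ccc(NC(=O)c4cc(-c5ccccc5C)ccn4)cc3F)ccnc2cc1OCCCN1CCN(C)CC1` gives 180 nM in a functional assay on HT-29 cells (Homo sapiens) for cytotoxicity, read by MTT assay, with a stated time of 72 h; on this read-out higher numbers stand for weaker inhibition and lower numbers for stronger inhibition. Compound 2 `COc1cc2c(Oc3ccc(NC(=O)c4cc(-c5ccc(C(F)(F)F)cc5)ccn4)cc3F)ccnc2cc1OCCCN1CCN(C)CC1` gives 200 nM. Compound 3 `COc1ccc(-c2ccnc(C(=O)Nc3ccc(Oc4ccnc5cc(OCCCN6CCN(C)CC6)c(OC)cc45)c(F)c3)c2)cc1` gives 390 nM, the highest of the three numbers; its gap to compound 2 is within the scatter, while a 2.2-fold higher number from compound 1 to compound 3 (0.34 log units; beyond the scatter).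

Compound 4 `COc1ccc(-c2ccnc(C(=O)Nc3ccc(Oc4ccnc5cc(OCCCN6CCN(C)CC6)c(OC)cc45)c(F)c3)c2)c(OC)c1` is not yet measured. It differs from compound 3 by methoxy in place of hydrogen on an aromatic carbon, so the ring now carries two methoxy groups.

Going by the values given here, none of the measured steps adds a group to this ring; they swap one group for another. Those swaps moved the numbers only modestly: a 1.1-fold higher number from compound 1 to compound 2 (0.05 log units; within the scatter) and a 2.0-fold higher number from compound 2 to compound 3 (0.29 log units; within the scatter). Since changes on this ring have shifted the read-out little, a second methoxy is expected to leave the number close to that of compound 3, with no step beyond the scatter in either direction.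

Compound 4 is therefore estimated at 400 nM in this assay, within a range from 180 nM to 900 nM, which means an expected step of a 1.0-fold higher number from compound 3 to compound 4 (0.01 log units; within the scatter).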

Compound 4, half-maximal inhibitory concentration: 420 nM
Estimate against measurement, compound 4: 1.1-fold (0.02 log units) below, and the stated range covers the measured number.
By their numbers in this assay, from the lowest: compounds 1, 2, 3 and 4 (each within the scatter of the next, the first and the last beyond it).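

Compound 3 and compound 4 show what happens when a group is added to this ring rather than swapped for another. Placing a methoxy ortho to a large group and meta to a methoxy group gives a 1.1-fold higher number from compound 3 to compound 4 (0.03 log units; within the scatter) in this assay, so the two compounds cannot be told apart and this position accepts the extra methoxy without a readable change. The wider comparisons, a 2.1-fold higher number from compound 2 to compound 4 (0.32 log units; beyond the scatter) and a 2.3-fold higher number from compound 1 to compound 4 (0.37 log units; beyond the scatter), are modest but both lie beyond the scatter, and they leave the 2,4-dimethoxyphenyl compound at the high end of the set, level with compound 3 within the scatter; nothing at hand explains these numbers.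

Going by these compounds, it remains open whether a different kind of group at this position, such as an amine, a carboxylic acid or a longer chain in place of the methoxy, would also leave the number almost unmoved. With only one cell line shown, it is also open whether the same small differences would hold in other cells.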